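The source may report more compounds than this note shows. Statements on the series, on what has been measured and on what is new or still open speak of the compounds shown alone.

Measured in a functional assay on HL-60 cells (Homo sapiens) for cytotoxicity, read by MTT assay, with a stated time of 72 h; on this read-out lower numbers stand for stronger inhibition and higher numbers for weaker inhibition:
- compound 1 `Nc1cccc(Nc2nc3ccccc3nc2S(=O)(=O)c2ccccc2)c1`: 1750 nM
- compound 2 `COc1ccc(S(=O)(=O)c2nc3ccccc3nc2Nc2ccccc2)cc1`: 260 nM
- compound 3 `COc1ccc(S(=O)(=O)c2nc3ccccc3nc2Nc2cc(OC)cc(OC)c2)cc1`: 1710 nM

Compound 3 lies within the scatter of compound 1, and its number stands well above that of compound 2. Next is compound 4 `COc1ccc(S(=O)(=O)c2nc3ccccc3nc2Nc2cccc(N)c2)cc1`, with this change: 3-aminophenyl in place of 3,5-dimethoxyphenyl on a nitrogen on an aromatic ring. Within the data shown here, one measured step bears on it: a 6.6-fold higher number from compound 2 to compound 3 (0.82 log units; beyond the scatter), which ends on the same 3,5-dimethoxyphenyl. Leaving that group may therefore lower the number. Compound 1 carries 3-aminophenyl at 1750 nM, but differs from compound 4 elsewhere, which argues for caution. The expected change is a 2.9-fold lower number from compound 3 to compound 4 (0.45 log units; beyond the scatter), a modest drop. For compound 4 the estimated value in this assay is 600 nM, with an expected range of 170 nM to 2000 nM.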

Compound 4, half-maximal inhibitory concentration: 1490 nM
Compound 4: the middle estimate sits 2.5-fold (0.40 log units) below what was measured, and the stated range covers the measured number.
By their numbers in this assay, from the lowest: compound 2; then compounds 4, 3 and 1 (each within the scatter of the next).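

In this assay, 3-aminophenyl and 3,5-dimethoxyphenyl on the nitrogen are not told apart (a 1.1-fold lower number from compound 3 to compound 4 (0.06 log units; within the scatter)). Adding amino to the phenyl of compound 2 gives a 5.7-fold higher number from compound 2 to compound 4 (0.76 log units; beyond the scatter) so in this small set, both substituted rings on that nitrogen stand above the unsubstituted phenyl. With 3-aminophenyl in place, methoxy in place of hydrogen on an aromatic carbon leaves the number within the scatter (a 1.2-fold lower number from compound 1 to compound 4 (0.07 log units; within the scatter)).

As far as these compounds go, whether a hydroxyl or a morpholine on that ring would match the unsubstituted phenyl stays open. Nothing at hand explains these steps.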